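The source may report more compounds than this note shows. Statements on the series, on what has been measured and on what is new or still open speak of the compounds shown alone.

Of the compounds shown here, two have been tested in an assay on membranes from brain (strain Sprague-Dawley) for displacement of a labelled ligand from metabotropic glutamate receptor 5 (Rattus norvegicus), read by scintillation counting, with a stated time of 60 min; on this read-out higher numbers stand for weaker inhibition and lower numbers for stronger inhibition. Compound 1 `CC(=O)c1cccc(C#Cc2cc(F)cc(C#N)c2)n1` carries an acetyl group on the shared core, and in this assay compound 1 gives 64 nM. Compound 2 `CCCCc1cccc(C#Cc2cccc(C#N)c2)n1` carries a butyl group instead, and in this assay compound 2 gives 45 nM. These two numbers lie within the scatter of each other, so neither compound can be called stronger than the other.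

Compound 3 `CC(=O)c1cccc(C#Cc2cccc(C#N)c2)n1` has not yet been measured. It differs from compound 2 in one place: acetyl in place of butyl on an aromatic carbon. Within the data shown here, no measured pair shows this exact exchange on its own. Compound 1, which also carries an acetyl group, gives 64 nM, so the exchange is expected to move the number little, and any change from compound 2 to compound 3 is expected to stay within the scatter. The estimated value for compound 3 in this assay is 60 nM, with a likely range from 25 nM to 150 nM, and the expected step is a 1.3-fold higher number from compound 2 to compound 3 (0.12 log units; within the scatter).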

Compound 3, inhibition constant: 114 nM
For compound 3 the middle estimate is 1.9-fold (0.28 log units) below the measured one; the range from low to high includes it.
By their numbers in this assay, from the lowest: compounds 2, 1 and 3 (each within the scatter of the next, the first and the last beyond it).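

In this assay, among these compounds, acetyl in place of butyl on the aromatic carbon next to the ring nitrogen gives a 2.5-fold higher number from compound 2 to compound 3 (0.40 log units; beyond the scatter) and so provides the first direct reading of this exchange: on this shared core, the position responds modestly to the choice between these two groups, with the butyl compound showing the stronger inhibition. Hydrogen in place of fluoro on an aromatic carbon gives a 1.8-fold higher number from compound 1 to compound 3 (0.25 log units; within the scatter) and so shows no difference that can be separated from the usual scatter between this acetyl pair. The data offer no measured explanation for the gap between butyl and acetyl.

As far as these compounds go, it remains open whether a propyl group, a longer chain such as hexyl, or an amine at this position would read closer to butyl or to acetyl. Also open, from the compounds shown here alone, is whether adding fluoro to compound 2 would again leave the number within the scatter.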